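Hydroxy in place of 4-methylpiperazin-1-yl on the chain

This account rests on a few compounds, and the source may have more. Where it says the series, first, only, none or still open, it means among the compounds named here.

Of the compounds shown here, three sharing one core have been read in a functional assay on HL60/MX2 cells (Homo sapiens) for antiproliferative activity, read by MTT assay, with a stated time of 48 h; on this read-out higher numbers stand for weaker inhibition and lower numbers for stronger inhibition. They differ only on a saturated chain carbon, two bonds along the chain from an aromatic nitrogen. Compound 1 (`CCN(CC)CCn1c(N)c(-c2nc3ccccc3[nH]2)c2nc(C#N)c(C#N)nc21`) gives 7150 nM. Compound 3 (`CN1CCN(CCn2c(N)c(-c3nc4ccccc4[nH]3)c3nc(C#N)c(C#N)nc32)CC1`) gives 6490 nM. Compound 2 (`N#Cc1nc2c(-c3nc4ccccc4[nH]3)c(N)n(CCN3CCCC3)c2nc1C#N`) gives > 50000 nM, which is a limit of the assay and not a number.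

Compound 3 therefore stands level with compound 1, as shown by a 1.1-fold lower number from compound 1 to compound 3 (0.04 log units; within the scatter). Its separation from the limit reading is an at least 7.7-fold lower number from compound 2 to compound 3 (0.88 log units; beyond the scatter).

Compound 4 (`N#Cc1nc2c(-c3nc4ccccc4[nH]3)c(N)n(CCO)c2nc1C#N`) has hydroxy in place of 4-methylpiperazin-1-yl, a change counted as hydroxy in place of 4-methylpiperazin-1-yl on a saturated chain carbon, two bonds along the chain from an aromatic nitrogen. Among the measured compounds shown here, no measured step puts hydroxy at this place, so the exchanges among the three compounds are the only guide. Those exchanges are uneven: a 1.1-fold lower number from compound 1 to compound 3 (0.04 log units; within the scatter) stays within the scatter, whereas an at least 6.9-fold higher number from compound 1 to compound 2 (0.84 log units; beyond the scatter) goes beyond it. A change here can thus leave this assay unmoved or raise the number markedly.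

A modest move to a higher number is expected, with wide uncertainty: a 2.3-fold higher number from compound 3 to compound 4 (0.36 log units; beyond the scatter). For compound 4 the estimated value is 15000 nM, with an expected range of 4000 nM to 50000 nM.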

Compound 4, half-maximal inhibitory concentration: > 50000 nM
Compound 4: no number, only a limit; the forecaster's own chance of this, stated with the estimate: 30%; at least 3.3-fold (0.52 log units) between middle value and limit.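

In this assay compound 4 gives > 50000 nM, which is a limit of the assay and not a number. Hydroxy on the chain parts from both groups that gave a number, with an at least 7.7-fold higher number from compound 3 to compound 4 (0.88 log units; beyond the scatter) and an at least 6.9-fold higher number from compound 1 to compound 4 (0.84 log units; beyond the scatter), so the position holds diethylamino and 4-methylpiperazin-1-yl level but does not accept every exchange, and the loss is no longer confined to pyrrolidin-1-yl; having an amine on the chain is still not sufficient, since compound 2 goes against any simple split of amines from hydroxy. The step between compound 2 and compound 4 cannot be read, so these two stay unordered, and part of the series now rests on a single reading: the limit of > 50000 nM in this assay, at which 2 of the 4 values shown sit.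

Still open, going by these compounds, is whether the loss seen with hydroxy carries over to methoxy, a primary amine or a carboxylic acid at this place, or to a longer chain bearing 4-methylpiperazin-1-yl. Morpholine or piperidine on the same chain would test whether the gap between pyrrolidin-1-yl and 4-methylpiperazin-1-yl follows the ring itself, a question the four compounds shown cannot settle.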